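A few compounds are considered here, and "the series" means these few. Any claim that something is new, unique, unknown or untested is made for them only; others in the source may bear on it.

Measured in a functional assay, with a stated time of 10 min; on this read-out lower numbers stand for stronger inhibition and higher numbers for weaker inhibition:
- compound 1 `COc1ccccc1/C=C/c1cc(=O)c(O)c[nH]1`: 6740 nM
- compound 2 `Cn1cc(O)c(=O)cc1/C=C/c1ccccc1`: 2110 nM
- compound 3 `Cn1cc(O)c(=O)cc1/C=C/c1ccc(Cl)cc1`: 5720 nM

Compound 2 has the lowest number of the three. Compound 4 `COc1ccccc1/C=C/c1cc(=O)c(O)cn1C` differs from it by methoxy in place of hydrogen on an aromatic carbon. Among the measured compounds shown here, one measured step bears on this change, the modest 2.7-fold higher number from compound 2 to compound 3 (0.43 log units; beyond the scatter), although it involves chloro rather than methoxy. For the measured compounds named here, compound 1 also carries methoxy and gives 6740 nM, but its core differs from that of compound 4, so no measured pair isolates methoxy. A modest rise in the number is therefore expected in this assay. The expected change is a 1.8-fold higher number from compound 2 to compound 4 (0.26 log units; within the scatter). The estimate for compound 4 is 3800 nM, with an expected range of 1600 nM to 9000 nM.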

Compound 4, half-maximal inhibitory concentration: 4170 nM
Compound 4: middle estimate off by 1.1-fold (0.04 log units), on the low side; low and high end bracket the measured number.
By their numbers in this assay, from the lowest: compounds 2, 4, 3 and 1 (each within the scatter of the next, the first and the last beyond it).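

In this assay, methoxy in place of hydrogen on an aromatic carbon, ortho to a large group, gives a 2.0-fold higher number from compound 2 to compound 4 (0.30 log units; within the scatter) and so stays inside the scatter, which means this position accepts methoxy with no change that can be read. Compound 4 also supplies a matched pair for methyl in place of hydrogen on an aromatic nitrogen, and a 1.6-fold lower number from compound 1 to compound 4 (0.21 log units; within the scatter) is likewise inside the scatter. No measurement here accounts for either step.

Still open, as far as these compounds go, is whether an amine or a carboxylic acid at this aromatic carbon would match methoxy. Also open, from the compounds shown here alone, is whether a longer chain on the nitrogen would match methyl.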